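The compounds below may be only part of what the source reports. "The series", "measured", "known", "first", "only" and "open" are said of these compounds alone.

Measured so far:
compound 1 `C=CCNC(=S)NC1=C(C#N)C(c2ccc(Cl)cc2Cl)C2=C(CCCC2=O)N1c1ccc(S(N)(=O)=O)cc1`: 30%
compound 2 `N#CC1=C(N2C(=O)CCC2=O)N(c2ccc(S(N)(=O)=O)cc2)C2=C(C(=O)CCC2)C1c1ccc(Cl)cc1Cl`: 50%

For the measured compounds named here, in a functional assay on Ehrlich cells (Mus musculus) for cytotoxicity, read by trypan blue exclusion, with a stated time of 2 h, tested at 25 ug/mL (on this read-out higher numbers stand for a stronger effect at the one concentration tested and lower numbers for a weaker effect), compound 2 gives 50%, the highest of the two numbers; the only other number is that of compound 1, and the single measured step, a number 20 percentage points higher from compound 1 to compound 2 (beyond the scatter), is the whole of what is known about changing this position. Compound 3 `N#CC1=C(NS(=O)(=O)c2ccc(Br)cc2)N(c2ccc(S(N)(=O)=O)cc2)C2=C(C(=O)CCC2)C1c1ccc(Cl)cc1Cl` differs from compound 2 by ((4-bromophenyl)sulfonyl)amino in place of 2,5-dioxopyrrolidin-1-yl on a double-bonded ring carbon. That measured step bears on the new change only loosely: it shows that swapping the group on this double-bonded ring carbon can shift the read-out by a modest amount, but it says nothing about the direction for a ((4-bromophenyl)sulfonyl)amino group. Since the group that gave the higher number is the one leaving, a modest move downward, or none beyond the scatter, is the expectation, giving a number 10 percentage points lower from compound 2 to compound 3 (within the scatter). For compound 3 the estimate is 40%, within 15% to 65%.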

Compound 3, a percentage reported as activity, at one concentration (the size of the read-out at that concentration, not a potency): 90%
Compound 3: middle estimate off by 50 percentage points, on the low side; measured number above the stated range.
By their numbers in this assay, from the lowest: compound 1; then compound 2; then compound 3.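

In this assay, the group on this double-bonded ring carbon proves able to move the read-out far more than the first step suggested: ((4-bromophenyl)sulfonyl)amino in place of 2,5-dioxopyrrolidin-1-yl gives a number 40 percentage points higher from compound 2 to compound 3 (beyond the scatter). The nitrogen on the ring carbon can also stay in place while the group on it changes, and the aromatic sulfonyl group of compound 3 in place of the open-chain group of compound 1 gives a number 60 percentage points higher from compound 1 to compound 3 (beyond the scatter). Nothing measured here explains why this change has so large an effect.

The compounds shown do not separate the contributions of the bromine, the benzene ring and the sulfonyl link, all of which enter together. A phenylsulfonylamino group without bromine, a methylsulfonylamino group or a 4-bromobenzoylamino group would begin to pull these parts apart.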